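Swapping a Benzyl Ether for a Chlorophenyl Ether

This account rests on a few compounds, and the source may have more. Where it says the series, first, only, none or still open, it means among the compounds named here.

Among the measured compounds shown here, compound 1 `O=C1NC(=O)C(Cc2ccc(OCc3ccccc3)cc2)S1` is one of three compounds measured in a functional assay for agonist activity at Free fatty acid receptor 1 (Homo sapiens), read by FLIPR, in the presence of a further agent that is not named here; a lower number here means that less compound is needed, a higher number that more compound is needed for the effect. In this assay compound 1 gives 6180 nM, the second highest of the three numbers. Compound 3 `O=C1CC(Cc2ccc(Oc3ccc(Cl)cc3Cl)cc2)C(=O)N1`, which is built on a different core, gives 6450 nM, a value that lies within the usual scatter of compound 1. Compound 2 `O=C1NC(=O)C(Cc2ccc(-c3ccccc3)cc2)S1`, which lacks the ether oxygen, gives 2220 nM, a lower number that lies beyond the scatter when set against compound 1.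

Compound 4 `O=C1NC(=O)C(Cc2ccc(Oc3ccccc3Cl)cc2)S1` has not yet been measured. It differs from compound 1 in one place: 2-chlorophenyl in place of benzyl on an oxygen on an aromatic ring. For the measured compounds named here, the oxygen now joins two aromatic rings, as it does in compound 3, although compound 3 carries a different core and a different chlorine pattern, so no measured pair shows this exact step.

With only these three numbers to go on, the step from compound 1 to compound 4 is expected to be small, at most a modest move toward a lower number, and it may well stay within the scatter. Compound 4 is therefore expected to give about 3500 nM, with a likely range from 1200 nM to 10000 nM. This corresponds to an expected step of a 1.8-fold lower number from compound 1 to compound 4 (0.25 log units; within the scatter).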

Compound 4, half-maximal effective concentration: 1190 nM
The estimate for compound 4 lay 2.9-fold (0.47 log units) above the measured number, and the stated range ends above it.
By their numbers in this assay, from the lowest: compounds 4 and 2 (each within the scatter of the next); then compounds 1 and 3 (each within the scatter of the next).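

In this assay, among the compounds shown here, the step from benzyl to 2-chlorophenyl on the oxygen gives a 5.2-fold lower number from compound 1 to compound 4 (0.72 log units; beyond the scatter), which lies beyond the scatter and is the first measured change at this position with the core held constant. The position therefore responds to what is attached to the oxygen, even though the group that leaves and the group that enters have the same count of heavy atoms, each hold one six-membered aromatic ring of carbon only, and neither has a hydrogen-bond donor or acceptor, so these counts alone do not predict the result. Nothing measured here explains why the number falls, and no separate data on these compounds bear on it.

This single step changes two things at once: the carbon that linked the ring to the oxygen is gone, and a chlorine has appeared, so the compounds shown cannot separate the contribution of each. A plain phenyl on the same oxygen would divide the step into those two parts, while 2-methylphenyl or 4-chlorophenyl would show whether the chlorine and its place on the ring matter.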